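Trimming a side chain on a shared core

A few compounds are considered here, and "the series" means these few. Any claim that something is new, unique, unknown or untested is made for them only; others in the source may bear on it.

Measured so far:
- compound 1, `COC(CCn1cnc2c(NCc3ccc(C(=O)Nc4ccccc4N)cc3)nc(Cl)nc21)OC`: 43.7% in a functional assay on NCI-H460 cells (Homo sapiens) for antiproliferative activity, read by CCK-8 assay, with a stated time of 72 h, tested at 2 uM; on this read-out lower numbers stand for a weaker effect and higher numbers for a stronger effect at the one concentration tested
- compound 2, `Nc1ccccc1NC(=O)/C=C/c1ccc(Cn2cnc3c(NCc4ccccc4)nc(Cl)nc32)cc1`: 4.62% in this assay

Compound 1 stands highest of the two numbers; compound 2 lies well below it, beyond the usual scatter. Compound 2 differs from compound 1 in more than one place, so the two values show only that gap and nothing about any single change.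

The next compound is compound 3, `CCCn1cnc2c(NCc3ccc(C(=O)Nc4ccccc4N)cc3)nc(Cl)nc21`. It differs from compound 1 by methyl in place of dimethoxymethyl on a saturated chain carbon, two bonds along the chain from an aromatic nitrogen. Among the compounds with values here, no pair of measured compounds differs in this place alone, so there is no measured step to lean on. The change is confined to a short chain, and the rest of compound 1 is kept. The step from compound 1 to compound 3 is therefore expected to be small, at most a mild loss and likely within the scatter, as a number 5.7 percentage points lower from compound 1 to compound 3 (within the scatter). Compound 3 is estimated at 38%, in the range 18% to 58%.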

Compound 3, a percentage reported as inhibition, at one concentration (the size of the read-out at that concentration, not a potency): 31%
For compound 3 the middle estimate is 7 percentage points above the measured one; the range from low to high includes it.
By their numbers in this assay, from the lowest: compound 2; then compound 3; then compound 1.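

Within the data shown here, replacing the 3,3-dimethoxypropyl chain with propyl gives a number 12.7 percentage points lower from compound 1 to compound 3 (beyond the scatter) in this assay and is the first change measured at this place alone. It shows that the group on this saturated chain carbon affects the reading, although the effect is modest: compound 3, with its plain propyl chain, still gives 31% at the one concentration tested. No measurement here bears on why the number falls with this change.

The compounds shown leave open how an amine, a carboxylic acid or a longer chain would read at this place. With one replacement, they also cannot separate the loss of the two oxygen atoms from the loss of the other heavy atoms in dimethoxymethyl, which a methoxymethyl group might begin to address.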